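Shortening the chain to the piperazine: compound 1 to compound 3

The source may report more compounds than this note shows. Statements on the series, on what has been measured and on what is new or still open speak of the compounds shown alone.

Of the compounds shown here, two of this core carry numbers so far. Compound 1 `CN1CCN(CCCCn2c3c(c4ccccc42)C(=O)c2c[n+]([O-])c4ccccc4c2C3=O)CC1` gives 90 nM in a functional assay on A549 cells (Homo sapiens) for cytotoxicity, read by MTT assay, with a stated time of 72 h; on this read-out higher numbers stand for weaker inhibition and lower numbers for stronger inhibition; compound 2 `CC1(C)OC[C@H](Cn2cc(Cn3c4c(c5ccccc53)C(=O)c3c[n+]([O-])c5ccccc5c3C4=O)nn2)O1` gives 340 nM in this assay. Compound 1 thus stands with the lower of the two numbers, and its gap to compound 2 lies beyond the scatter. Within the data shown here, no pair of measured compounds differs in a single place, so the series offers no calibrated step for any structural change.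

Compound 3 `CN1CCN(CCCn2c3c(c4ccccc42)C(=O)c2c[n+]([O-])c4ccccc4c2C3=O)CC1` has not been measured. It differs from compound 1 by 4-methylpiperazin-1-yl in place of (4-methylpiperazin-1-yl)methyl on a saturated chain carbon, three bonds along the chain from an aromatic nitrogen. The change only shortens the saturated chain between the aromatic nitrogen and the piperazine ring, which itself is kept unchanged. Among the measured compounds shown here, with no measured pair of this kind to lean on, the step of a 1.2-fold higher number from compound 1 to compound 3 (0.09 log units; within the scatter) is expected to be small, with no direction beyond the scatter for compound 3. Compound 3 is therefore estimated at 110 nM in this assay, with a range from 50 nM to 250 nM.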

Compound 3, half-maximal inhibitory concentration: 140 nM
For compound 3 the middle estimate is 1.3-fold (0.10 log units) below the measured one, within the range that was stated.
By their numbers in this assay, from the lowest: compounds 1 and 3 (each within the scatter of the next); then compound 2.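

In this assay the series now has its first calibrated step, a 1.6-fold higher number from compound 1 to compound 3 (0.19 log units; within the scatter), and it concerns the saturated chain on the aromatic nitrogen of the shared core. With the 4-methylpiperazin-1-yl ring kept, going from 4-(4-methylpiperazin-1-yl)butyl to 3-(4-methylpiperazin-1-yl)propyl gives no change beyond the scatter, so for these two chains this read-out does not separate the lengths. No measured data on the compounds offer an explanation for this result, and nothing can be said about what lies behind it.

Still open, going by these compounds, is whether this holds for a shorter chain such as 2-(4-methylpiperazin-1-yl)ethyl or for a chain longer than butyl, since two chain lengths fix no trend in either direction. Also open, on these data alone, is what happens when the chain is kept and the 4-methylpiperazin-1-yl ring gives way to another amine such as morpholine or piperidine, or to a carboxylic acid. Compound 2 differs from both compound 1 and compound 3 in more than one place and cannot answer this.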